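Aryl nitro variant of compound 1: expected cytotoxicity

The compounds below may be only part of what the source reports. "The series", "measured", "known", "first", "only" and "open" are said of these compounds alone.

Measured compounds:
compound 1 `COc1ccc(/C=C\C(=O)O)c(OCc2cn(-c3ccccc3)nn2)c1CC=C(C)C` — 29200 nM
compound 2 `COc1ccc(/C=C\C(=O)O)c(OCc2cn(-c3ccccc3C(=O)N3CCC(O)C3)nn2)c1CC=C(C)C` — "not determined" (no result reported)

Going by the values given here, in a functional assay on NCI-H322 cells (Homo sapiens) for cytotoxicity, read by MTT assay, with a stated time of 24 h (a higher number here means a weaker inhibitor, a lower number a stronger inhibitor), compound 1 gives 29200 nM, the only number in this small set; compound 2 gives "not determined" (no result reported), so compound 1 stands alone and is a weak inhibitor in this assay. Compound 3 `COc1ccc(/C=C\C(=O)O)c(OCc2cn(-c3cccc([N+](=O)[O-])c3)nn2)c1CC=C(C)C` differs from compound 1 by nitro in place of hydrogen on an aromatic carbon, the same difference cut one bond further out reading phenyl to 3-nitrophenyl. Among the compounds with values here, no pair of measured compounds differs in a single place, so no measured step is available to calibrate this change. Given the weak anchor of compound 1 at 29200 nM, the step to compound 3 is expected to stay within the scatter, a 1.3-fold lower number from compound 1 to compound 3 (0.12 log units; within the scatter), with no clear direction. Compound 3 is therefore estimated at 22000 nM in this assay, with a range from 7000 nM to 70000 nM.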

Compound 3, half-maximal inhibitory concentration: 43200 nM
Estimate against measurement, compound 3: 2.0-fold (0.29 log units) below; low and high end bracket the measured number.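

In this assay, going by these compounds alone, the first measured step is a 1.5-fold higher number from compound 1 to compound 3 (0.17 log units; within the scatter) and so gives the first reading at this position. Nitro in place of hydrogen on an aromatic carbon, meta to a large group, is tolerated here without separating compound 3 from compound 1, and both remain weak inhibitors in this assay. No supporting data bear on why this change leaves the read-out within the scatter.

Steps involving compound 2 cannot be read, as it has no number, so this single pair is the only comparison in the series. Open, as far as these compounds go, is whether any group at this position moves the number beyond the scatter, for example an amine or a carboxylic acid on the same ring carbon, or nitro on a different carbon of that ring.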